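This account rests on a few compounds, and the source may have more. Where it says the series, first, only, none or still open, it means among the compounds named here.

Of the compounds shown here, three of a shared core have been tested in an assay on cells for displacement of a labelled ligand from adenosine receptor A2b (Homo sapiens), read by scintillation counting and radioligand binding, with a stated time of 30 min, tested at 10 uM; on this read-out higher numbers stand for more inhibition at the one concentration tested (going by the name of the read-out) and lower numbers for less inhibition. Compound 1 `CN1CCN(c2nc(-c3ccc(Cl)c(C(F)(F)F)c3)nc3[nH]cnc23)CC1` gives 25.1%. Compound 2 `CN1CCN(c2nc(-c3cc(Cl)ccc3Cl)nc3[nH]cnc23)CC1` gives 13%, and compound 3 `Clc1ccc(Cl)c(-c2nc(N3CCCCC3)c3nc[nH]c3n2)c1` gives 12.1%. Compound 2 thus stands second of the three numbers: its value lies close to that of compound 3, within the usual scatter, while the number for compound 1 is higher by an amount beyond the scatter.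

Compound 4 `CN1CCN(c2nc(-c3ccc(O)cc3)nc3[nH]cnc23)CC1` is not yet measured. It differs from compound 2 in one place: 4-hydroxyphenyl in place of 2,5-dichlorophenyl on an aromatic carbon.

Among the measured compounds shown here, only one measured step between neighbours exists, from compound 2 to compound 3, and it amounted to a number 0.9 percentage points lower from compound 2 to compound 3 (within the scatter), but it concerns the 4-methylpiperazin-1-yl group and not the aryl ring that changes here. For the measured compounds named here, no measured step tells how the read-out in this assay responds to an exchange of the aryl ring, so the expectation can rest only on the spread of the three numbers, which all lie in the lower part of the scale. The step from compound 2 to compound 4 is therefore expected to be a number 1 percentage points higher from compound 2 to compound 4 (within the scatter), which is no change beyond the scatter. Compound 4 is estimated to give 14%, with a range from 0% to 32%.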

Compound 4, a percentage reported as inhibition, at one concentration (the size of the read-out at that concentration, not a potency): 53%
Beside the measured number, compound 4's estimate is 39 percentage points below it; measured number above the stated range.
By their numbers in this assay, from the lowest: compounds 3 and 2 (each within the scatter of the next); then compound 1; then compound 4.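

In this assay, the aryl ring on the aromatic carbon between two ring nitrogen atoms proves to be a place where the read-out responds strongly: exchanging 2,5-dichlorophenyl for 4-hydroxyphenyl gives a number 40 percentage points higher from compound 2 to compound 4 (beyond the scatter). Among the compounds shown here, the only earlier step, a number 0.9 percentage points lower from compound 2 to compound 3 (within the scatter), concerned the amine group at another place on the shared core, so this is the first sign that the read-out can move far with a single exchange on this scaffold. The exchange removes both chlorine atoms and brings in a ring carrying a hydrogen-bond donor and acceptor, but no measurement here explains the rise.

The compounds shown leave open whether the gain comes from the hydroxy group itself, from the loss of the two chlorine atoms, or from both, since these changes arrive together in one step. Plain phenyl, 4-methoxyphenyl or 4-aminophenyl at this position would help separate these possibilities, and pairing 4-hydroxyphenyl with piperidin-1-yl would show whether the gain holds when the 4-methylpiperazin-1-yl group is replaced.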